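The source may hold more compounds than are shown below. What is called first, only, known or untested is meant among the compounds shown, and "the series" means these compounds.

Of the compounds shown here, two built on a shared core have been measured so far. Compound 1 `COc1cc(Nc2nc(C(=N)Nc3ccccc3)cc3c(-c4ccccc4)n[nH]c23)cc(OC)c1OC` gives 4500 nM in a functional assay on MDA-MB-231 cells (Homo sapiens) for cytotoxicity, read by MTT assay, with a stated time of 72 h; a higher number here means a weaker inhibitor, a lower number a stronger inhibitor. Compound 2 `N=C(Nc1ccccc1)c1cc2c(-c3ccccc3)n[nH]c2c(NC2CCCCC2)n1` gives 1710 nM in this assay. Within the data shown here, the single change between them, cyclohexyl in place of 3,4,5-trimethoxyphenyl on a nitrogen on an aromatic ring, brought a 2.6-fold lower number from compound 1 to compound 2 (0.42 log units; beyond the scatter). Compound 2 therefore holds the lowest of the two numbers, and compound 1 stands higher by a step that lies beyond the scatter.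

Compound 3 `COc1ccc(Cn2nc(-c3ccccc3)c3cc(C(=N)Nc4ccccc4)nc(NC4CCCCC4)c32)cc1` has not yet been measured. It differs from compound 2 by 4-methoxybenzyl in place of hydrogen on an aromatic nitrogen. Among the measured compounds shown here, the one measured step concerns a different nitrogen, the one bearing the cyclohexyl group, and says nothing about the position changed here. Nothing in the numbers at hand tells in which direction this change should move this assay, or whether it moves it at all beyond the scatter. The expectation therefore stays close to compound 2, with a wide range. For compound 3 the expected step is a 1.2-fold higher number from compound 2 to compound 3 (0.07 log units; within the scatter). Compound 3 is estimated at 2000 nM, within a range from 500 nM to 8000 nM.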

Compound 3, half-maximal inhibitory concentration: 3400 nM
Compound 3: the middle estimate sits 1.7-fold (0.23 log units) below what was measured, and the stated range covers the measured number.
By their numbers in this assay, from the lowest: compounds 2, 3 and 1 (each within the scatter of the next, the first and the last beyond it).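

Compound 3 carries 4-methoxybenzyl where compound 2 has a hydrogen on the aromatic nitrogen of the five-membered ring, and in this assay this change gives a 2.0-fold higher number from compound 2 to compound 3 (0.30 log units; within the scatter). The earlier compounds shown here said nothing about this position; this pair shows that the hydrogen there is not needed to keep the cytotoxic read-out, since a group of 9 heavy atoms with its own six-membered aromatic ring can take its place without a step beyond the usual scatter of the assay. Nothing measured here accounts for this result, and a single pair cannot show how the size or the make-up of the group on this nitrogen relates to the number read out.

The compounds shown leave open whether a small methyl, an unsubstituted benzyl or a longer chain ending in an amine or a carboxylic acid on this nitrogen would also stay within the scatter of compound 2. They also leave open whether 4-methoxybenzyl would behave the same way on compound 1, which carries 3,4,5-trimethoxyphenyl instead of cyclohexyl on the other nitrogen.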